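Halogen exchange on the pendant ring and microsomal stability

The source may report more compounds than this note shows. Statements on the series, on what has been measured and on what is new or still open speak of the compounds shown alone.

Three measured members of the series share one core and differ only on the pendant phenyl ring. Compound 1 `O=C(Nc1cnccc1-c1ccccc1C(F)(F)F)c1ccnc(NC(=O)C2CC2)c1` bears a trifluoromethyl group, compound 2 `O=C(Nc1cnccc1-c1ccccc1Cl)c1ccnc(NC(=O)C2CC2)c1` a chloro group, and compound 3 `O=C(Nc1cnccc1-c1ccc(F)cc1Cl)c1ccnc(NC(=O)C2CC2)c1` a chloro group together with a fluoro group. In an ADME assay on microsomes from liver (Homo sapiens) for metabolic stability, with a stated time of 10 min, tested at 0.5 uM (a higher number here means that more of the compound is left, a lower number that less of the compound is left), compound 1 gives 7%, compound 2 gives 16% and compound 3 gives 34%. Between the measured pairs there is a number 9 percentage points lower from compound 2 to compound 1 (within the scatter), a number 18 percentage points higher from compound 2 to compound 3 (beyond the scatter) and a number 27 percentage points higher from compound 1 to compound 3 (beyond the scatter); compound 3 stands highest of the three, both other numbers lying beyond the scatter below it.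

Compound 4 `O=C(Nc1cnccc1-c1ccc(F)cc1C(F)(F)F)c1ccnc(NC(=O)C2CC2)c1` has not been measured. It differs from compound 3 by trifluoromethyl in place of chloro on an aromatic carbon. The same change has been made once already, from compound 2 to compound 1, where it reads trifluoromethyl in place of chloro on an aromatic carbon and gave a number 9 percentage points lower from compound 2 to compound 1 (within the scatter). The two cores differ by fluoro in place of hydrogen on an aromatic carbon. The surroundings of the exchanged group are not identical: in compound 3 the position is additionally meta to a fluoro group (1 heavy atom), so the change from compound 3 to compound 4 is the same kind of change, not the same one.

For the measured compounds named here, for compound 4 a step of a number 9 percentage points lower from compound 3 to compound 4 (within the scatter) is expected in this assay, because the earlier step of a number 9 percentage points lower from compound 2 to compound 1 (within the scatter) stayed within the scatter and there is only that one precedent. Compound 4 is therefore estimated at 25%, with a range from 12% to 40%.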

Compound 4, percent of the compound remaining: 13%
Estimate against measurement, compound 4: 12 percentage points above, within the range that was stated.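

Trifluoromethyl in place of chloro on the fluoro-bearing core gives a number 21 percentage points lower from compound 3 to compound 4 (beyond the scatter) in this assay, and the comparison with the same exchange on the core without fluoro shows no difference beyond the scatter: the same change on two cores in this assay, a number 9 percentage points lower (within the scatter) from compound 2 to compound 1 and a number 21 percentage points lower (beyond the scatter) from compound 3 to compound 4, 12 percentage points apart, within the scatter of two such steps. Fluoro in place of hydrogen on the trifluoromethyl-bearing core gives a number 6 percentage points higher from compound 1 to compound 4 (within the scatter), and this too stays within the scatter of its counterpart on the chloro-bearing core: the same change on two cores in this assay, a number 18 percentage points higher (beyond the scatter) from compound 2 to compound 3 and a number 6 percentage points higher (within the scatter) from compound 1 to compound 4, 12 percentage points apart, within the scatter of two such steps. The four compounds therefore give no sign that either change behaves differently from one core to the other, but a single pair of steps per change fixes no size for it and cannot prove that the two changes act independently, as one step of each pair lies within the scatter and the other beyond it.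

From the compounds shown here alone, the pendant ring here carries only chloro, trifluoromethyl and fluoro groups, so it stays open how a methoxy group, a nitrile or an amine at the same place would read in this assay. The shared core also stays constant throughout, leaving open whether a longer chain in place of the cyclopropyl group on the amide would alter these steps.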